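This account rests on a few compounds, and the source may have more. Where it says the series, first, only, none or still open, it means among the compounds named here.

Working notes on the series. Compound 1 `CCc1nc(N)nc(N)c1C#CC(C)c1ccc(-c2ccccc2)cc1OC` gives, in an assay on isolated protein for inhibition of Dihydrofolate reductase (Homo sapiens), using NADPH, with a stated time of 5 min (a higher number here means a weaker inhibitor, a lower number a stronger inhibitor), a half-maximal inhibitory concentration of 172 nM. Of the two numbers recorded so far, compound 1 holds the higher one, with compound 2 `CCc1nc(N)nc(N)c1C#CC(C)c1ccc(-c2ccc(F)cc2)cc1OC` at 148 nM in this assay; the step of a 1.2-fold lower number from compound 1 to compound 2 (0.07 log units; within the scatter) lies within the scatter, so the two compounds are not separated by the data. That step, fluoro in place of hydrogen on an aromatic carbon, concerns the phenyl group and not the methoxy.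

Compound 3 `CCc1nc(N)nc(N)c1C#CC(C)c1ccc(-c2ccccc2)cc1` differs from compound 1 by hydrogen in place of methoxy on an aromatic carbon. Going by the values given here, no measured step touches the methoxy, so there is no direct precedent for this change; the only step seen so far was within the scatter. The expectation for compound 3 in this assay is therefore a modest step of a 2.0-fold higher number from compound 1 to compound 3 (0.31 log units; beyond the scatter), with a wide range, and the estimate is 350 nM with a range from 120 nM to 1000 nM.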

Compound 3, half-maximal inhibitory concentration: 174 nM
Beside the measured number, compound 3's estimate is 2.0-fold (0.30 log units) above it; the range from low to high includes it.
By their numbers in this assay, from the lowest: compounds 2, 1 and 3 (each within the scatter of the next).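

In this assay, going by these compounds alone, the step of a 1.0-fold higher number from compound 1 to compound 3 (0.01 log units; within the scatter) is the first reading at this position, on an aromatic carbon ortho to a large group and meta to a phenyl group, and it lies within the scatter. The methoxy, with its 2 heavy atoms and 1 hydrogen-bond acceptor, can thus give way to hydrogen without the data separating compound 3 from compound 1, so this pair gives no sign that the methoxy is needed for inhibition at this level. Nothing measured here bears on why this change leaves the number unseparated.

Still open, from the compounds shown here alone, is whether any group on this carbon separates from hydrogen and methoxy, for example a hydroxyl, a chlorine or a longer ether chain such as ethoxy. Also open, going by these compounds, is whether the same holds with the fluoro group of compound 2 present, as this change is read only on the parent phenyl group of compound 1.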